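This account rests on a few compounds, and the source may have more. Where it says the series, first, only, none or still open, it means among the compounds named here.

Compound 1 `N#C/C(=C\c1ccc[nH]1)C(=O)NCc1ccc(Cl)c(Cl)c1` and compound 2 `N#C/C(=C\c1ccco1)C(=O)NCc1ccc(Cl)c(Cl)c1` share a core that carries a nitrile and an amide. In a functional assay on SJ-G2 cells (Homo sapiens) for inhibition, read by MTT assay, with a stated time of 72 h (a lower number here means a stronger inhibitor of growth, a higher number a weaker inhibitor of growth), compound 1 gives only a limit, > 50000 nM. Compound 2 likewise gives only a limit in this assay, > 50000 nM. The step that the two limits leave unreadable from compound 1 to compound 2 cannot be read because both values sit at the limit of > 50000 nM in this assay, at which 2 of the 3 values shown sit. Compound 3 `COc1ccc(CNC(=O)/C(C#N)=C/c2ccc(Cl)o2)cc1` gives 13000 nM in this assay. Compound 4 `N#C/C(=C\c1ccccc1)C(=O)NCc1ccc(Cl)c(Cl)c1` differs from compound 2 by phenyl in place of furan-2-yl on a double-bonded chain carbon bound to a double-bonded chain carbon. Among the compounds with values here, no measured step touches phenyl at this place, and the only step at this place is unreadable. With compound 2 at a limit, the estimated step of an at least 1.2-fold lower number from compound 2 to compound 4 (0.09 log units; that floor lies within the scatter) is expected to be small and probably again unreadable. Compound 4 is expected to give about 40000 nM, between 8000 nM and 200000 nM.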

Compound 4, concentration for 50% growth inhibition: 43000 nM
Beside the measured number, compound 4's estimate is 1.1-fold (0.03 log units) below it; the range from low to high includes it.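

Among the compounds sharing its amide side, compound 4 alone gives a number rather than a limit in this assay, so phenyl at this place brings a readable value. Yet phenyl in place of furan-2-yl gives an at least 1.1-fold lower number from compound 2 to compound 4 (0.06 log units; that floor lies within the scatter), and phenyl in place of 1H-pyrrol-2-yl gives an at least 1.1-fold lower number from compound 1 to compound 4 (0.06 log units; that floor lies within the scatter), and neither floor lies beyond the scatter, so no gain for phenyl can be claimed. The step between the other two rings still cannot be read: the limit of > 50000 nM in this assay, at which 2 of the 4 values shown sit.

From the compounds shown here alone, what an amine or a carboxylic acid on the phenyl ring would do to this value remains open.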